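The source may report more compounds than this note shows. Statements on the series, on what has been measured and on what is new or still open speak of the compounds shown alone.

Measured so far in an in vivo functional assay on the whole organism for inhibition, with Rattus norvegicus as the target; a higher number here means that more compound is needed for the effect, a lower number that less compound is needed
Compound 1 `CCCCc1nc(C)c(CC(=O)N2CCC[C@H]2C(N)=O)c(=O)n1Cc1ccc(-c2ccccc2-c2nnn[nH]2)cc1` gives 0.023 mg/kg
Compound 2 `CCCCc1nc(C)c(CCC(=O)N2CC(C)OC(C)C2)c(=O)n1Cc1ccc(-c2ccccc2-c2nnn[nH]2)cc1` gives 0.228 mg/kg

Compound 2 holds the higher of the two numbers. Compound 3 `CCCCc1nc(C)c(CC(=S)N(CC)CC)c(=O)n1Cc1ccc(-c2ccccc2-c2nnn[nH]2)cc1` departs from compound 2 through a group of 7 heavy atoms (5 carbon, 1 nitrogen, 1 sulfur; no ring) in place of a group of 11 heavy atoms (8 carbon, 1 nitrogen, 2 oxygen; one six-membered non-aromatic ring with 2 hetero atoms), on a saturated chain carbon bound to an aromatic carbon and keeps the rest of the structure. For the measured compounds named here, only one measured step bears on this change: a 9.9-fold higher number from compound 1 to compound 2 (1.00 log units; beyond the scatter), which lies beyond the scatter and falls on a saturated chain carbon bound to an aromatic carbon. With that single step as the guide, a smaller move towards a lower number is expected in this assay, estimated as a 2.3-fold lower number from compound 2 to compound 3 (0.36 log units; beyond the scatter) overall. For compound 3 the estimate is 0.1 mg/kg, with an expected range from 0.02 mg/kg to 0.5 mg/kg in this reading.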

Compound 3, dose for half-maximal effect: 0.023 mg/kg
Estimate against measurement, compound 3: 4.3-fold (0.64 log units) above; the measured number falls inside the stated range.
By their numbers in this assay, from the lowest: compounds 1 and 3 (each within the scatter of the next); then compound 2.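

At this saturated chain carbon bound to an aromatic carbon, the sulfur-bearing group without a ring gives a 9.9-fold lower number from compound 2 to compound 3 (1.00 log units; beyond the scatter) in this assay. Set against the other ring-bearing group, the same group gives no change at the digits printed from compound 1 to compound 3 (within the scatter), so a ring in this substituent is not required for a number at that level. Nothing measured here explains either step.

Whether the sulfur itself matters stays open, as the same group with a carbonyl in its place is not among the compounds shown. Going by these compounds, how a carboxylic acid or an amine would fare at this position also remains unknown.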